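The source may hold more compounds than are shown below. What is called first, only, known or untested is meant among the compounds shown, and "the series" means these compounds.

Compound 1 `O=[N+]([O-])c1ccc(NC(=S)NCCNS(=O)(=O)c2ccc(-c3ccccc3OCc3ccccc3)s2)cc1` gives 11300 nM in a functional assay on RS4-11 cells (Homo sapiens) for inhibition, read by CCK-8 assay, with a stated time of 48 h; on this read-out lower numbers stand for stronger inhibition and higher numbers for weaker inhibition.
Compound 2 `CC(C)c1ccc(Oc2ccc(O)c(O)c2)c(-c2ccsc2S(=O)(=O)NCCNC(=S)Nc2ccc([N+](=O)[O-])cc2)c1` gives 5100 nM in this assay.
Compound 3 `O=C(NCCNS(=O)(=O)c1ccc(-c2ccccc2OCc2ccccc2)s1)Nc1cc(Cl)cc(Cl)c1` gives only a limit of the assay in this assay, > 20000 nM.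

Within this set, compound 2 carries the lowest number, and compound 1 the nearest one. The cores of compound 1 and compound 2 differ, but the difference between the two cores is not broken down here. From compound 1 to compound 3 the change is a group of 11 heavy atoms (7 carbon, 1 nitrogen, 1 oxygen, 2 chlorine; one six-membered aromatic ring of carbon only) in place of a group of 12 heavy atoms (7 carbon, 2 nitrogen, 2 oxygen, 1 sulfur; one six-membered aromatic ring of carbon only), on an amine nitrogen, and the step is an at least 1.7-fold higher number from compound 1 to compound 3 (0.24 log units; that floor lies within the scatter), reaching (the limit of > 20000 nM in this assay, at which 1 of the 3 values shown sits).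

Compound 4 `CC(C)c1ccc(Oc2ccc(O)c(O)c2)c(-c2ccsc2S(=O)(=O)NCCNC(=O)Nc2cc(Cl)cc(Cl)c2)c1` is not yet measured. It stands to compound 2 as compound 3 stands to compound 1, with the same change: a group of 11 heavy atoms (7 carbon, 1 nitrogen, 1 oxygen, 2 chlorine; one six-membered aromatic ring of carbon only) in place of a group of 12 heavy atoms (7 carbon, 2 nitrogen, 2 oxygen, 1 sulfur; one six-membered aromatic ring of carbon only), on an amine nitrogen. From the compounds shown here alone, since the earlier step ended at a limit, its true size is unknown; the expected step from compound 2 to compound 4 is estimated as a 2.9-fold higher number from compound 2 to compound 4 (0.47 log units; beyond the scatter), a weakening of about the same kind. Compound 4 is thus estimated at 15000 nM.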

Compound 4, half-maximal inhibitory concentration: 6400 nM
Estimate against measurement, compound 4: 2.3-fold (0.37 log units) above; measured number inside the range.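

In this assay, placing (3,5-dichlorophenyl)carbamoyl on the amine nitrogen of the core of compound 2 gives a 1.3-fold higher number from compound 2 to compound 4 (0.10 log units; within the scatter), so on this core the change has no effect that can be told from the scatter. Set beside the same change on the other core, the result reads: the same change on two cores in this assay, an at least 1.7-fold higher number (0.24 log units; that floor lies within the scatter) from compound 1 to compound 3 and a 1.3-fold higher number (0.10 log units; within the scatter) from compound 2 to compound 4; the limit leaves it open whether they differ. Compound 3 gives > 20000 nM, which is a limit of the assay, so this pair shows neither that the change carries over at one size nor that its size depends on the core.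

The compounds shown leave open how the numbers would respond to other groups on this amine nitrogen, such as an acetyl group or a simple benzoyl group. They also leave open what a longer chain would do in place of the saturated chain that carries this nitrogen.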